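The source may hold more compounds than are shown below. What is called first, only, known or untested is meant among the compounds shown, and "the series" means these compounds.

The set comprises three measured compounds and one that is not yet measured, all judged in a functional assay on SW480 cells (Homo sapiens) for cytotoxicity, read by MTT assay, with a stated time of 24 h; on this read-out higher numbers stand for weaker inhibition and lower numbers for stronger inhibition. Compound 1 `C=CC1=C(C(=O)NCc2ccc(Cl)cc2)C(c2ccc(F)cc2)OC1` opens the series. In this assay compound 1 reaches only the limit of the assay, > 100000 nM, which is a limit and not a number. Compound 2 `C=CC1=C(C(=O)NCc2ccc(Cl)cc2)C(c2ccc(OC)cc2)OC1` differs from compound 1 by methoxy in place of fluoro on an aromatic carbon. In this assay compound 2 also gives only the limit > 100000 nM. The step that the two limits leave unreadable from compound 1 to compound 2 is therefore not readable, because the limit of > 100000 nM in this assay, at which 3 of the 3 values shown sit, holds both of its values.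

Compound 3 `C=CC1=C(C(=O)NCc2ccc(OC)c(OC)c2)C(c2ccc(F)cc2)OC1` has a different core from compound 1, and the difference between the two cores is not broken down here. In this assay compound 3 likewise stands at the limit > 100000 nM, a limit rather than a number.

Compound 4 `C=CC1=C(C(=O)NCc2ccc(OC)c(OC)c2)C(c2ccc(OC)cc2)OC1` is related to compound 3 by methoxy in place of fluoro on an aromatic carbon. This is the same change as the one from compound 1 to compound 2, made at a place described in identical words, and it appears in two pairs among the compounds shown. Its measured size is unreadable from a step that the two limits leave unreadable from compound 1 to compound 2. For compound 4 the expected step is a number no higher from compound 3 to compound 4 (the limit leaves the size open) in this assay, resting on the fact that compound 1, compound 2 and compound 3 all sit at the limit of > 100000 nM in this assay, at which 3 of the 3 values shown sit. The estimate for compound 4 is 100000 nM, with a range from 40000 nM to 300000 nM, and most probably again only a limit.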

Compound 4, half-maximal inhibitory concentration: 13500 nM
Compound 4: the middle estimate sits 7.4-fold (0.87 log units) above what was measured; the measured number lies below the stated range.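

In this assay, methoxy in place of fluoro on an aromatic carbon gives an at least 7.4-fold lower number from compound 3 to compound 4 (0.86 log units; beyond the scatter), so on the core of compound 3 the change from 4-fluorophenyl to 4-methoxyphenyl goes with stronger inhibition. On the core of compound 1 the same change leads to compound 2, which stands at > 100000 nM, a limit and not a number. This shows that the change does not bring a measurable number on every core, but it does not show that the change does nothing on the core of compound 1, and the two pairs cannot be compared in size, because the step from compound 1 to compound 2 cannot be read and the step on the core of compound 3 starts from a limit: the limit of > 100000 nM in this assay, at which 3 of the 4 values shown sit.

With only two pairs carrying the change, the compounds shown leave open whether the stronger inhibition of compound 4 comes from the 4-methoxyphenyl group on any core or only from its combination with the core of compound 3. They also leave open how an amine, a carboxylic acid or a longer chain in place of the methoxy would read in this assay.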